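The source may hold more compounds than are shown below. What is called first, only, known or untested is meant among the compounds shown, and "the series" means these compounds.

Working notes on the series. Compound 1 `Cc1cc(C)c(S(C)(=O)=O)cc1C(=O)N=C(N)N` gives 11 nM in a functional assay for inhibition of sodium/hydrogen exchanger (Oryctolagus cuniculus); on this read-out lower numbers stand for stronger inhibition and higher numbers for weaker inhibition. Compound 3 `Cc1cc(OC(C)C)c(S(C)(=O)=O)cc1C(=O)N=C(N)N` gives 19 nM in this assay, the second-highest of the three numbers; the step of a 1.7-fold higher number from compound 1 to compound 3 (0.24 log units; within the scatter) lies within the scatter. Compound 2 `Cc1cc(-c2cc(Cl)cc(Cl)c2)c(S(C)(=O)=O)cc1C(=O)N=C(N)N` gives 130 nM in this assay, with a 12-fold higher number from compound 1 to compound 2 (1.07 log units; beyond the scatter) and a 6.8-fold lower number from compound 2 to compound 3 (0.84 log units; beyond the scatter). Compound 4 `Cc1cc(OC2CCCC2)c(S(C)(=O)=O)cc1C(=O)N=C(N)N` is not yet measured; it differs from compound 3 by cyclopentyl in place of isopropyl on an oxygen on an aromatic ring. The steps bearing on this change are a 1.7-fold higher number from compound 1 to compound 3 (0.24 log units; within the scatter), small, and a 12-fold higher number from compound 1 to compound 2 (1.07 log units; beyond the scatter), large for a far bulkier group at the aromatic carbon; one five-membered non-aromatic ring of carbon only in place of isopropyl is a smaller change, and the expected step is a 1.3-fold higher number from compound 3 to compound 4 (0.12 log units; within the scatter), not beyond the scatter. Compound 4 is expected near 25 nM, range 8 nM to 80 nM.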

Compound 4, half-maximal inhibitory concentration: 27 nM
Estimate against measurement, compound 4: 1.1-fold (0.03 log units) below; measured number inside the range.
By their numbers in this assay, from the lowest: compounds 1, 3 and 4 (each within the scatter of the next, the first and the last beyond it); then compound 2.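

In this assay, cyclopentyl in place of isopropyl on an oxygen on an aromatic ring gives a 1.4-fold higher number from compound 3 to compound 4 (0.15 log units; within the scatter), so a ring on this oxygen cannot be told from the open chain. Against the methyl of compound 1, cyclopentyloxy gives a 2.5-fold higher number from compound 1 to compound 4 (0.39 log units; beyond the scatter), a step beyond the scatter that isopropoxy did not give, and it still stands well clear of 3,5-dichlorophenyl with a 4.8-fold lower number from compound 2 to compound 4 (0.68 log units; beyond the scatter). Nothing on hand gives a cause for these steps.

Open, as far as these compounds go, is how an amine or a longer alkoxy chain on this aromatic carbon would read, and whether cyclohexyl on the oxygen would stay within the scatter of compound 3.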